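Chain-end exchange on the compound 2 scaffold

The compounds below may be only part of what the source reports. "The series", "measured", "known", "first", "only" and "open" are said of these compounds alone.

Among the compounds with values here, compound 2 `COCC[S+]([O-])CC1CN(C)CCC1c1ccc(Cl)cc1` stands highest of the two numbers so far in an assay on isolated protein for inhibition of Norepinephrine transporter (Rattus norvegicus), read by radioligand binding (on this read-out lower numbers stand for stronger inhibition and higher numbers for weaker inhibition), giving 25 nM; its nearest neighbour is compound 1 `COCCSCC1CN(C)CCC1c1ccc(Cl)cc1`, which in this assay gives 6 nM. Within the data shown here, the single measured step, a 4.2-fold higher number from compound 1 to compound 2 (0.62 log units; beyond the scatter), alters the sulfur itself and leaves the chain end untouched. Compound 3 `CN1CCC(c2ccc(Cl)cc2)C(C[S+]([O-])CC(=O)N(C)C)C1` keeps the chain of compound 2 and differs from it only at that end: dimethylcarbamoyl in place of methoxymethyl on a saturated chain carbon bound to a sulfur. Among the measured compounds shown here, no measured step touches this part of the molecule, so the series gives no direct guide to this exchange; the one step available, a 4.2-fold higher number from compound 1 to compound 2 (0.62 log units; beyond the scatter), is modest and concerns a different part of the chain. The expectation is therefore a step of a 1.2-fold higher number from compound 2 to compound 3 (0.08 log units; within the scatter), not beyond the scatter, with wide uncertainty. Compound 3 is estimated at 30 nM, range 10 nM to 100 nM.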

Compound 3, inhibition constant: 1250 nM
Beside the measured number, compound 3's estimate is 42-fold (1.62 log units) below it; measured number above the stated range.
By their numbers in this assay, from the lowest: compound 1; then compound 2; then compound 3.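

Notes on the chain end: this end of the chain, left unchanged in the earlier step, proves highly sensitive in this assay, with a 50-fold higher number from compound 2 to compound 3 (1.70 log units; beyond the scatter); this exceeds the change at sulfur, a 4.2-fold higher number from compound 1 to compound 2 (0.62 log units; beyond the scatter). Methoxymethyl and dimethylcarbamoyl have equal hydrogen-bond donor and acceptor counts and no net charge, so these counts do not separate them; the differences that remain are the heavy-atom count and the double bond outside aromatic rings. Nothing available here accounts for the size of this step.

Still open, going by these compounds, is whether the carbonyl or the two methyl groups on nitrogen track with this large step, a question that a chain ending in a methyl ketone, a primary amide, a carboxylic acid or an amine could address. Also open, on these data alone, is whether dimethylcarbamoyl would have a similar effect with the sulfur of compound 1.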